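Working notes on a four-compound series with one open measurement

The source may hold more compounds than are shown below. What is called first, only, known or untested is meant among the compounds shown, and "the series" means these compounds.

Compound 1 `Cn1c(=O)[nH]c2ccc(OCCc3cccc(Cl)c3)cc21`, compound 3 `Cn1c(=O)[nH]c2ccc(OCCCc3ccccc3)cc21` and compound 2 `CC1(C)C(=O)Nc2ccc(OCc3cccc(Cl)c3)cc21` have been measured in an assay on cells for inhibition of Amine oxidase [flavin-containing] B (Homo sapiens), read by fluorescence, with stated times of 30 min and 15 min, tested at 1 uM; a lower number here means less inhibition, a higher number more inhibition at the concentration tested (going by the name of the read-out). In this assay compound 1 gives 13.7%, compound 3 gives 14% and compound 2 gives 21.1%; all three numbers lie within the scatter of one another, so no order among them is read.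

Among the compounds with values here, the one counted change inside the measured set is benzyl in place of 3-chlorophenyl on a saturated chain carbon, two bonds along the chain from an oxygen on an aromatic ring. The step that it made is a number 0.3 percentage points higher from compound 1 to compound 3 (within the scatter), which is no movement beyond the scatter. The difference between the core of compound 1 and the core of compound 2 is not broken down here.

Compound 4 `CC1(C)C(=O)Nc2ccc(OCCc3ccccc3)cc21` has not yet been measured. It differs from compound 2 by benzyl in place of 3-chlorophenyl on a saturated chain carbon bound to an oxygen on an aromatic ring. Within the data shown here, this is the same kind of change as the one from compound 1 to compound 3, but the place is not the same: in compound 4 the entering group sits on a saturated chain carbon bound to an oxygen on an aromatic ring, whereas in compound 3 it sits on a saturated chain carbon, two bonds along the chain from an oxygen on an aromatic ring.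

Because a number 0.3 percentage points higher from compound 1 to compound 3 (within the scatter) stayed within the scatter, a similarly flat step is expected here, a number 1.1 percentage points lower from compound 2 to compound 4 (within the scatter). Compound 4 is therefore estimated at 20% in this assay. The expected range for compound 4 runs from 8% to 32%. This rests on a single measured pair and on nothing else.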

Compound 4, a percentage reported as inhibition, at one concentration (the size of the read-out at that concentration, not a potency): "not active" (no number reported)
For compound 4 the study gives words and no number; no gap can be computed for the estimate.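

In this assay, within the data shown here, compound 4 is reported in words only, without a number, so no step from compound 2 to compound 4 can be read. The compounds shown leave open whether benzyl in place of 3-chlorophenyl on a saturated chain carbon bound to an oxygen on an aromatic ring shifts the read-out on the core of compound 2. No supporting data bear on this result.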